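A Halogen Swap Repeated on a Second Core

This account rests on a few compounds, and the source may have more. Where it says the series, first, only, none or still open, it means among the compounds named here.

Measured compounds:
compound 1, `CC1=C(C(=O)Nc2ccc(F)cc2)C(c2ccc([N+](=O)[O-])cc2)N=C(SCc2ccc(Cl)cc2)N1` — 39.7%
compound 2, `CC1=C(C(=O)Nc2ccc(F)cc2)C(c2ccc([N+](=O)[O-])cc2)N=C(SCc2ccc(F)cc2)N1` — 33%
compound 3, `COc1ccc(C2N=C(SCc3ccc(Cl)cc3)NC(C)=C2C(=O)Nc2ccc(Br)cc2)cc1` — 39.2%

Of the compounds shown here, three have been tested in a functional assay on the whole organism (artery, strain albino) with Rattus norvegicus as the target, with a stated time of 360 min, at a dose of 10 mg/kg by the oral route; a lower number here means less inhibition, a higher number more inhibition at the dose given (going by the name of the read-out). Compound 1 gives 39.7%, and compound 2 gives 33%. The two share one core and differ in a single place, (fluoro in place of chloro on an aromatic carbon), and that change produced a number 6.7 percentage points lower from compound 1 to compound 2 (within the scatter), a step that lies inside the usual scatter of this measurement.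

Compound 3 carries a different core; the difference between the core of compound 1 and the core of compound 3 is not broken down here. In this assay compound 3 gives 39.2%, close to the number for compound 1 and also near the number for compound 2, all within the scatter of one another.

Compound 4, `COc1ccc(C2N=C(SCc3ccc(F)cc3)NC(C)=C2C(=O)Nc2ccc(Br)cc2)cc1`, is not yet measured. It differs from compound 3 by fluoro in place of chloro on an aromatic carbon, the same change, in the same place, as that from compound 1 to compound 2. For the measured compounds named here, because the one measured example of this change gave a number 6.7 percentage points lower from compound 1 to compound 2 (within the scatter), the step from compound 3 to compound 4 is expected to be of similar size, about a number 5.2 percentage points lower from compound 3 to compound 4 (within the scatter). Going by the values given here, on that basis compound 4 is estimated to give roughly 34% in this assay, expected to fall between 22% and 46%, with the single prior example the only support.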

Compound 4, a percentage reported as inhibition, in the whole organism at one dose (the size of the read-out at that dose, not a potency): 33.5%
Beside the measured number, compound 4's estimate is 0.5 percentage points above it, and the stated range covers the measured number.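

In this assay, exchanging the 4-chlorobenzyl group for the 4-fluorobenzyl group on the core of compound 3 gives a number 5.7 percentage points lower from compound 3 to compound 4 (within the scatter), and this step can be set beside the one seen earlier on the core of compound 1: the same change on two cores in this assay, a number 6.7 percentage points lower (within the scatter) from compound 1 to compound 2 and a number 5.7 percentage points lower (within the scatter) from compound 3 to compound 4, 1 percentage points apart, within the scatter of two such steps

Within this small series, the change therefore reads alike on two cores, which themselves differ in more than one place, and nothing in these two steps separates one core from the other. What this does not show is that the exchange has a real effect on the read-out, since each step taken alone stays inside the usual scatter, and agreement between two cores says nothing about whether the same would hold on a third.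

The compounds shown leave open whether any other group in that place on the benzyl ring, such as a nitrile, an amine or a carboxylic acid, would give a step that clears the scatter. They also leave open what a longer chain in place of the benzyl group would do to the inhibition at this single oral dose.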